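A few compounds are considered here, and "the series" means these few. Any claim that something is new, unique, unknown or untested is made for them only; others in the source may bear on it.

Compound 1 `Cc1ccc(S(=O)(=O)Oc2cccc(/C=C(\C#N)C(=O)Nc3nnc(-c4cccs4)s3)c2)cc1`: 43%
Compound 2 `CC(=O)Nc1ccc(S(=O)(=O)Oc2cccc(/C=C(\C#N)C(=O)Nc3nnc(-c4cccs4)s3)c2)cc1`: 20%

Within the data shown here, in an ADME assay on HEK-293T cells (Homo sapiens) for inhibition, read by CCK-8 assay, with a stated time of 48 h, tested at 20 uM (a higher number here means more inhibition of growth at the concentration tested, a lower number less inhibition of growth), compound 1 gives 43%, the higher of the two numbers so far. Compound 3 `N#C/C(=C\c1cccc(NS(=O)(=O)c2ccc(F)cc2)c1)C(=O)Nc1nnc(-c2cccs2)s1` has not yet been measured. It differs from compound 1 in one place: ((4-fluorophenyl)sulfonyl)amino in place of ((4-methylphenyl)sulfonyl)oxy on an aromatic carbon. In words, ((4-fluorophenyl)sulfonyl)amino stands in place of ((4-methylphenyl)sulfonyl)oxy on an aromatic carbon, meta to a large group, while the rest of the molecule stays the same.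

Among the measured compounds shown here, only one measured step offers any guidance: a number 23 percentage points lower from compound 1 to compound 2 (beyond the scatter). That modest step, beyond the usual scatter, put acetamido in place of methyl within the group that is replaced in compound 3. For the measured compounds named here, it is an imperfect guide, as no measured compound shows what happens when the oxy link becomes amino, or when fluoro is present. It does show that a change in this part of compound 1 can move the reading, so a somewhat smaller drop is expected here, with wide uncertainty. The expected step, as an estimate, is a number 13 percentage points lower from compound 1 to compound 3 (beyond the scatter). For compound 3 the estimated value is 30%, with an expected range of 10% to 55%.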

Compound 3, percent growth inhibition at one concentration: 29%
Compound 3: the middle estimate sits 1 percentage points above what was measured, and the stated range covers the measured number.
By their numbers in this assay, from the lowest: compounds 2 and 3 (each within the scatter of the next); then compound 1.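

In this assay the change gives a number 14 percentage points lower from compound 1 to compound 3 (beyond the scatter). Compound 2 altered only the far end of the group at this position, whereas compound 3 shows that the reading also moves when the ((4-methylphenyl)sulfonyl)oxy group is replaced by ((4-fluorophenyl)sulfonyl)amino, a group with the same number of heavy atoms but with 1 hydrogen-bond donor where the group that leaves has 0. The link to the ring and the substituent on the far ring change together in this step, so its size cannot be divided between them, and no measurement shown explains why the reading moved.

The compounds shown leave open which of the two changes matters more, a question that the ((4-methylphenyl)sulfonyl)amino and ((4-fluorophenyl)sulfonyl)oxy groups could settle by each changing only one of them. They also leave open how the reading would respond to other substituents on the far ring, such as an amine or a carboxylic acid in place of the fluoro.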